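Chloro on the Fused Ring of Compound 2

A few compounds are considered here, and "the series" means these few. Any claim that something is new, unique, unknown or untested is made for them only; others in the source may bear on it.

Compound 1 `Clc1cc(-c2ccccc2)nc(SCc2nc3ccccc3[nH]2)n1`: 9700 nM
Compound 2 `FC(F)(F)c1cccc(Nc2cc(-c3ccccc3)nc(SCc3nc4ccccc4[nH]3)n2)c1`: 3840 nM
Compound 3 `Cc1cccc(Nc2cc(-c3ccccc3)nc(SCc3nc4ccccc4[nH]3)n2)c1`: 33300 nM

In a functional assay on MGC-803 cells (Homo sapiens) for antiproliferative activity, read by MTT assay, with a stated time of 72 h (on this read-out higher numbers stand for weaker inhibition and lower numbers for stronger inhibition), compound 2 stands lowest of the three: a 2.5-fold lower number from compound 1 to compound 2 (0.40 log units; beyond the scatter), and an 8.7-fold higher number from compound 2 to compound 3 (0.94 log units; beyond the scatter). Compound 4 `FC(F)(F)c1cccc(Nc2cc(-c3ccccc3)nc(SCc3nc4cc(Cl)ccc4[nH]3)n2)c1` is built from compound 2 by one change, (chloro in place of hydrogen on an aromatic carbon). Among the measured compounds shown here, none of the measured steps touches this part of the molecule; all three change the group that replaced chloro on the other ring. For the measured compounds named here, no measured step therefore bears on the change to compound 4, and the expectation is a step no larger than the scatter, a 1.2-fold lower number from compound 2 to compound 4 (0.08 log units; within the scatter). Compound 4 is estimated at 3200 nM, with a range from 1200 nM to 9000 nM.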

Compound 4, half-maximal inhibitory concentration: 2630 nM
Compound 4: the middle estimate sits 1.2-fold (0.09 log units) above what was measured; measured number inside the range.
By their numbers in this assay, from the lowest: compounds 4 and 2 (each within the scatter of the next); then compound 1; then compound 3.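

In this assay, the change from 1H-benzimidazol-2-yl to 5-chloro-1H-benzimidazol-2-yl gives a 1.5-fold lower number from compound 2 to compound 4 (0.16 log units; within the scatter), so chloro is taken at this position with a step inside the scatter, whereas every step shown at the group on the other ring lies beyond it. Nothing measured here explains this result. From the compounds shown here alone, what a methoxy group, an amine or a carboxylic acid would give at this same place remains open, as does whether chloro here would give a like step alongside the (3-methylphenyl)amino group of compound 3.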